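The source may hold more compounds than are shown below. What is called first, only, known or untested is meant among the compounds shown, and "the series" means these compounds.

Working notes on the series. In a functional assay on PC-3 cells (Homo sapiens) for cytotoxicity, read by MTT assay, with a stated time of 72 h (on this read-out lower numbers stand for stronger inhibition and higher numbers for weaker inhibition), compound 1 `CCCCCOCNc1n[n+]([O-])c2ccccc2[n+]1[O-]` gives 8510 nM, while compound 2 `CCCCCOCNc1n[n+]([O-])c2cc(OC)ccc2[n+]1[O-]` gives 30900 nM. Compound 1 thus has the lowest number of the two, with compound 2 nearest at a 3.6-fold higher number from compound 1 to compound 2 (0.56 log units; beyond the scatter) for methoxy in place of hydrogen on an aromatic carbon. Compound 3 `CCCCOCNc1n[n+]([O-])c2ccccc2[n+]1[O-]` differs from compound 1 by hydrogen in place of methyl on a saturated chain carbon, four bonds along the chain from an oxygen on a saturated carbon. For the measured compounds named here, no measured step addresses a change on the chain; the one step measured concerns only the aromatic substitution. In this assay compound 3 is therefore expected to show a 1.2-fold higher number from compound 1 to compound 3 (0.07 log units; within the scatter), a step not beyond the scatter. The estimate for compound 3 is 10000 nM, with a range of 4000 nM to 25000 nM.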

Compound 3, half-maximal inhibitory concentration: 6010 nM
Compound 3: the middle estimate sits 1.7-fold (0.22 log units) above what was measured, and the stated range covers the measured number.
By their numbers in this assay, from the lowest: compounds 3 and 1 (each within the scatter of the next); then compound 2.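

In this assay, hydrogen in place of methyl on a saturated chain carbon, four bonds along the chain from an oxygen on a saturated carbon, gives a 1.4-fold lower number from compound 1 to compound 3 (0.15 log units; within the scatter). Unlike the earlier aromatic step, this reading bears on the chain itself, and here the removal of one carbon leaves the two compounds within the scatter of each other. Nothing on hand accounts for this result. The compounds shown leave open whether a longer chain, or an amine at the chain end, would also stay within the scatter. They also leave open whether the methoxy step would hold on the shorter chain of compound 3.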